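Bromobenzoyl swap on the most growth-inhibiting compound

The source may hold more compounds than are shown below. What is called first, only, known or untested is meant among the compounds shown, and "the series" means these compounds.

Values in a functional assay on A549 cells (Homo sapiens) for inhibition, read by MTT assay, with a stated time of 24 h; a higher number here means a weaker inhibitor of growth, a lower number a stronger inhibitor of growth:
- compound 1 `COc1ccc2c(c1)c(-c1nc3ccccc3n1C(=O)c1ccccc1Br)cn2C`: 29500 nM
- compound 2 `Cn1cc(-c2nc3ccccc3n2C(=O)c2ccccc2)c2cc(Br)ccc21`: 23100 nM
- compound 3 `COc1ccc(C(=O)n2c(-c3cn(C)c4ccc(Br)cc34)nc3ccccc32)cc1OC`: 3400 nM

Compound 3 holds the lowest number of the three, beyond the scatter from both others. Moving to compound 4 `Cn1cc(-c2nc3ccccc3n2C(=O)c2ccccc2Br)c2cc(Br)ccc21` means (2-bromophenyl in place of 3,4-dimethoxyphenyl on a carbonyl carbon), with 2-bromophenyl in place of 3,4-dimethoxyphenyl on a carbonyl carbon. Within the data shown here, the one measured step bearing on this is a 6.8-fold lower number from compound 2 to compound 3 (0.83 log units; beyond the scatter), which went the other way, with 3,4-dimethoxyphenyl entering in place of phenyl. Compound 1 also carries 2-bromophenyl, on a different core, and sits at 29500 nM. A rise of similar size is expected for compound 4, giving an expected 5.9-fold higher number from compound 3 to compound 4 (0.77 log units; beyond the scatter). Compound 4 is estimated at 20000 nM, with an expected range of 9000 nM to 40000 nM.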

Compound 4, concentration for 50% growth inhibition: 46700 nM
The estimate for compound 4 lay 2.3-fold (0.37 log units) below the measured number, and the stated range ends below it.
By their numbers in this assay, from the lowest: compound 3; then compounds 2, 1 and 4 (each within the scatter of the next, the first and the last beyond it).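

In this assay, among these compounds, the group on the carbonyl carbon decides most of the outcome: 2-bromophenyl in place of 3,4-dimethoxyphenyl gives the largest step so far (a 14-fold higher number from compound 3 to compound 4 (1.14 log units; beyond the scatter)). Bromo in place of hydrogen on an aromatic carbon gives a much smaller step (a 2.0-fold higher number from compound 2 to compound 4 (0.31 log units; beyond the scatter)), and bromo in place of methoxy on an aromatic carbon of the core stays within the scatter (a 1.6-fold higher number from compound 1 to compound 4 (0.20 log units; within the scatter)). Nothing available explains these steps. From the compounds shown here alone, whether a single methoxy on the phenyl would suffice remains open, as does the effect of an amine or a carboxylic acid there.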